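The source may hold more compounds than are shown below. What is called first, only, known or untested is meant among the compounds shown, and "the series" means these compounds.

Compound 1 `O=C(Nc1ccccc1)c1c(O)c2cccnc2n(-c2ccccc2)c1=O`: 4.6%
Compound 2 `Cc1cccc(NC(=O)c2c(O)c3cccnc3n(-c3ccccc3)c2=O)c1`: 14.2%

In a functional assay on the whole organism for inhibition, with Rattus norvegicus as the target, read by paw edema, at a dose of 100 mg/kg by the oral route (a lower number here means less inhibition, a higher number more inhibition at the dose given (going by the name of the read-out)), compound 2 gives 14.2%, the higher of the two numbers shown, but only within the scatter of compound 1, since a number 9.6 percentage points higher from compound 1 to compound 2 (within the scatter). Compound 3 `Cc1ccccc1NC(=O)c1c(O)c2cccnc2n(-c2ccccc2)c1=O` differs from compound 2 by 2-methylphenyl in place of 3-methylphenyl on an amide-type nitrogen: the 3-methylphenyl leaves and the 2-methylphenyl enters on the amide-type nitrogen. Among the measured compounds shown here, the single measured step, a number 9.6 percentage points higher from compound 1 to compound 2 (within the scatter), concerns adding a methyl rather than moving one, and was itself within the scatter. The expectation is therefore a step of a number 3.2 percentage points lower from compound 2 to compound 3 (within the scatter), none beyond the scatter. Compound 3 is estimated at 11%, with a range from 0% to 26%.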

Compound 3, a percentage reported as inhibition, in the whole organism at one dose (the size of the read-out at that dose, not a potency): 11.7%
Estimate against measurement, compound 3: 0.7 percentage points below; the range from low to high includes it.
By their numbers in this assay, from the lowest: compounds 1, 3 and 2 (each within the scatter of the next).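

In this assay moving the methyl from the 3-methylphenyl to the 2-methylphenyl on the amide-type nitrogen gives a number 2.5 percentage points lower from compound 2 to compound 3 (within the scatter) and so the place of the methyl on this ring does not separate the two compounds. Methyl in place of hydrogen at this second place gives a number 7.1 percentage points higher from compound 1 to compound 3 (within the scatter) and so, like the first methyl, it does not separate its compound from the one without a methyl. No measurement at hand explains these numbers.

The compounds shown leave open whether a different group on this ring, such as an amine or a carboxylic acid, would give a step beyond the scatter in this assay.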